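The source may hold more compounds than are shown below. What is called first, only, known or untested is meant among the compounds shown, and "the series" means these compounds.

Series values in a functional assay on HCT-116 cells (Homo sapiens) for antiproliferative activity, read by CCK-8 assay, with a stated time of 72 h; a lower number here means a stronger inhibitor, a higher number a weaker inhibitor:

- compound 1 `CCC(C)n1cnc2c(NCc3ccc(C(=O)Nc4ccccc4N)cc3)nc(Cl)nc21`: 720 nM
- compound 2 `Nc1ccccc1NC(=O)c1ccc(Cn2cnc3c(NCc4ccccc4)nc(Cl)nc32)cc1`: 1060 nM
- compound 3 `Nc1ccccc1NC(=O)c1ccc(Cn2cnc3c(Nc4ccc(-c5ccccn5)cc4)nc(Cl)nc32)cc1`: 1250 nM

Compound 1 has a value within the scatter of those of compound 2 and compound 3, so these numbers support no ranking among the three. Still unmeasured is compound 4 `CC(C)n1cnc2c(NCc3ccc(C(=O)Nc4ccccc4N)cc3)nc(Cl)nc21`, which differs from compound 1 by one small change: hydrogen in place of methyl on a saturated chain carbon, two bonds along the chain from an aromatic nitrogen. This is hydrogen in place of methyl on a saturated chain carbon, two bonds along the chain from an aromatic nitrogen, so that sec-butyl becomes isopropyl.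

Within the data shown here, only one measured step between compounds differing in one place is available: a 1.2-fold higher number from compound 2 to compound 3 (0.07 log units; within the scatter). That step exchanges benzyl for 4-(pyridin-2-yl)phenyl on a nitrogen on an aromatic ring, so it bears only indirectly on the sec-butyl change. Among the measured compounds shown here, no measured step tests that change itself. The step from compound 2 still shows that even the exchange of a whole group stayed within the scatter in this assay, and the three values span little. No step beyond the scatter is therefore expected, in either direction. The expected step is a 1.1-fold higher number from compound 1 to compound 4 (0.03 log units; within the scatter). For compound 4 the estimated value is 780 nM, with an expected range from 370 nM to 1600 nM.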

Compound 4, half-maximal inhibitory concentration: 800 nM
The estimate for compound 4 lay 1.0-fold (0.01 log units) below the measured number; measured number inside the range.
By their numbers in this assay, from the lowest: compounds 1, 4, 2 and 3 (each within the scatter of the next).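

In this assay, among these compounds, sec-butyl and isopropyl at this place give a 1.1-fold higher number from compound 1 to compound 4 (0.05 log units; within the scatter), the only step that directly tests hydrogen in place of methyl on a saturated chain carbon, two bonds along the chain from an aromatic nitrogen. The earlier step, a 1.2-fold higher number from compound 2 to compound 3 (0.07 log units; within the scatter), concerned a different place, a nitrogen on an aromatic ring, so it could say nothing direct about this chain; the new pair shows that, in this read-out, the methyl can be exchanged for hydrogen with no change that stands out from the scatter. Among the compounds shown here, no measurement in hand bears on the reason for the size of this step, and it supports only this one pair of groups, not a rule for the position.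

The compounds shown leave open whether the position stays this flat across a wider range of groups, such as a plain methyl, a longer chain like n-hexyl, a cyclopentyl ring, or a chain ending in an amine. They also leave open whether the same exchange gives a similar step when the group on the other nitrogen of the shared core is different.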